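The source may report more compounds than this note shows. Statements on the series, on what has been measured and on what is new or still open speak of the compounds shown alone.

Series of aryl sulfonate esters carrying an amide or urea on the second ring. In a functional assay on HT-1080 cells (Homo sapiens) for antiproliferative activity, read by sulforhodamine B assay, with a stated time of 48 h (a lower number here means a stronger inhibitor, a higher number a weaker inhibitor), compound 1 `CC(C)C(=O)Nc1cccc(S(=O)(=O)Oc2ccccc2C(C)C)c1` gives 16000 nM, compound 2 `CC(C)c1ccccc1OS(=O)(=O)c1ccc(NC(=O)C(C)(C)C)cc1` gives 11000 nM, and compound 3 `CC(C)(C)C(=O)Nc1ccc(S(=O)(=O)Oc2ccccc2I)cc1` gives 2600 nM, the lowest of the three. For the measured compounds named here, the only single-point step known, a 4.2-fold lower number from compound 2 to compound 3 (0.63 log units; beyond the scatter), concerns the ring substituent and leaves the carbonyl end untouched; compounds 1 and 2 differ in two places at once, so their values allow no clean comparison. Compound 4 `O=C(Nc1ccc(S(=O)(=O)Oc2ccccc2I)cc1)NC1CC1` differs from compound 3 by cyclopropylamino in place of tert-butyl on a carbonyl carbon. Going by the values given here, no measured step bears on this change, so the expected step is a 1.2-fold higher number from compound 3 to compound 4 (0.06 log units; within the scatter), within the scatter and of uncertain direction. Compound 4 is estimated at 3000 nM, with a range of 1000 nM to 10000 nM.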

Compound 4, half-maximal inhibitory concentration: 1300 nM
The estimate for compound 4 lay 2.3-fold (0.36 log units) above the measured number; the range from low to high includes it.
By their numbers in this assay, from the lowest: compounds 4 and 3 (each within the scatter of the next); then compounds 2 and 1 (each within the scatter of the next).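

In this assay, for the compounds shown here, the step of a 2.0-fold lower number from compound 3 to compound 4 (0.30 log units; within the scatter) gives the first reading at the carbonyl end of the series. With the iodo ring held fixed, cyclopropylamino and tert-butyl on this carbonyl carbon cannot be told apart, so the urea of compound 4 and the amide of compound 3 sit within the scatter despite the added hydrogen-bond donor. No supporting measurement explains this result.

Open, from the compounds shown here alone, is whether a larger ring or a longer chain on the urea nitrogen, or a simple methylamino group, would read the same. Also open, going by these compounds, is whether the urea holds with isopropyl in place of iodo on the aromatic carbon.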